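Trifluoromethyl in place of chloro: growth-inhibition notes

The compounds below may be only part of what the source reports. "The series", "measured", "known", "first", "only" and "open" are said of these compounds alone.

In a functional assay on U-937 cells (Homo sapiens) for inhibition, read by MTT assay, with a stated time of 24 h (on this read-out higher numbers stand for weaker inhibition of growth and lower numbers for stronger inhibition of growth), compound 1 `Cc1cn(-c2cc(C(=O)Nc3cccc(C4=Nc5cnn(Cc6ccccc6)c5NC(=O)C4)c3)cc(C(F)(F)F)c2)cn1` gives > 30000 nM as a limit and not a number. For the measured compounds named here, compound 2 `COc1ccc(Cn2ncc3c2NC(=O)CC(c2cccc(NC(=O)Nc4cccc(Cl)c4)c2)=N3)cc1` stands at 630 nM in this assay and holds the only number so far. Compound 3 `COc1ccc(Cn2ncc3c2NC(=O)CC(c2cccc(NC(=O)Nc4cccc(C(F)(F)F)c4)c2)=N3)cc1` differs from compound 2 by one change trifluoromethyl in place of chloro on an aromatic carbon with trifluoromethyl in place of chloro on an aromatic carbon, meta to a large group. Going by the values given here, no measured step bears on this change, so no shift beyond the usual scatter is expected in this assay for it. The expected step is a 1.1-fold lower number from compound 2 to compound 3 (0.02 log units; within the scatter) and stays within that scatter. For compound 3 the estimated value is 600 nM with an expected range from 220 nM to 1800 nM in this assay.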

Compound 3, concentration for 50% growth inhibition: 280 nM
Compound 3: the middle estimate sits 2.1-fold (0.33 log units) above what was measured, within the range that was stated.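

In this assay, for the compounds shown here, trifluoromethyl in place of chloro on the aromatic carbon gives a 2.3-fold lower number from compound 2 to compound 3 (0.35 log units; beyond the scatter) and is the first step that can be read beyond the scatter. This position therefore responds to the change, and growth inhibition is modestly stronger with trifluoromethyl than with chloro. Nothing measured here accounts for the step.

On these data alone, whether other groups at this place, such as an amine, a carboxylic acid or a longer alkyl chain, keep or lose this growth inhibition remains open. A single pair also leaves open whether the same change gives a similar step on other compounds of the series.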